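The source may report more compounds than this note shows. Statements on the series, on what has been measured and on what is new or still open speak of the compounds shown alone.

Compound 1 `CCOc1cccc2cc(-c3ccccc3)c(=O)oc12` in a functional assay on CHO cells for antagonist activity at adenosine receptor A2b (Homo sapiens), read by cAMP accumulation; a lower number here means a stronger inhibitor, a higher number a weaker inhibitor: > 30000 nM, a limit of the assay, not a number.
Compound 2 `CCOc1cccc2cc(-c3ccc([N+](=O)[O-])cc3)c(=O)oc12` in this assay: > 30000 nM, also a limit.

Both values sit at the limit of > 30000 nM in this assay, at which 2 of the 2 values shown sit, so compound 1 stands only as a limit in this assay, and the step that the two limits leave unreadable from compound 1 to compound 2 cannot be read. Compound 3 `O=c1oc2c(O)cccc2cc1-c1ccccc1` differs from compound 1 by hydrogen in place of ethyl on an oxygen on an aromatic ring. No measured step bears on this change; the single step shown is unreadable. The expected step of a number no higher from compound 1 to compound 3 (the limit leaves the size open) is therefore none beyond the scatter, and a limit is again the most likely outcome. Compound 3 is estimated at 30000 nM, in the range 8000 nM to 100000 nM.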

Compound 3, half-maximal inhibitory concentration: > 30000 nM
Compound 3 was reported as a limit (the forecaster's own chance of this, stated with the estimate: 70%); the middle value sits exactly at the limit.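

Among the compounds shown here, no step from compound 1 to compound 3 can be read, as both values are limits and not numbers. In this assay the compounds shown leave open whether any change to the shared core gives a measurable value.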